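A few compounds are considered here, and "the series" means these few. Any claim that something is new, unique, unknown or untested is made for them only; others in the source may bear on it.

Compound 1 `CC(C)n1c(/C=C2/C(=O)Nc3ccc(F)cc32)nc2ccccc21` is the starting point of this small set. In a functional assay on A549 cells (Homo sapiens) for cytotoxicity, read by MTT assay, with a stated time of 48 h (on this read-out higher numbers stand for weaker inhibition and lower numbers for stronger inhibition), compound 1 gives 28500 nM. Compound 2 `Cn1c(/C=C2/C(=O)Nc3ccc(F)cc32)nc2ccccc21` carries the change methyl in place of isopropyl on an aromatic nitrogen and, in this assay, compound 2 gives 34600 nM, so the step of a 1.2-fold higher number from compound 1 to compound 2 (0.08 log units; within the scatter) amounts to no real movement. Compound 3 `CC(C)n1c(/C=C2/C(=O)Nc3ccc(Cl)cc32)nc2ccccc21` differs from compound 1 by the change (chloro in place of fluoro on an aromatic carbon); in this assay compound 3 gives 35200 nM, and the step of a 1.2-fold higher number from compound 1 to compound 3 (0.09 log units; within the scatter) likewise stays within the scatter. The three measured numbers therefore sit together, and none can be called the stronger or weaker inhibitor on this evidence.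

Compound 4 `Cn1c(/C=C2/C(=O)Nc3ccc(Cl)cc32)nc2ccccc21` is not yet measured. It differs from compound 3 by methyl in place of isopropyl on an aromatic nitrogen, which is the same change already seen between compound 1 and compound 2, at the same place. Because that earlier step a 1.2-fold higher number from compound 1 to compound 2 (0.08 log units; within the scatter) was flat, the step of a 1.1-fold higher number from compound 3 to compound 4 (0.06 log units; within the scatter) is expected to be flat as well. For compound 4 in this assay a value of 40000 nM is estimated, with a range from 24000 nM to 68000 nM.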

Compound 4, half-maximal inhibitory concentration: 39700 nM
Compound 4: middle estimate off by 1.0-fold (0.00 log units), on the high side, and the stated range covers the measured number.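

In this assay, methyl in place of isopropyl on the aromatic nitrogen again gives a flat step, a 1.1-fold higher number from compound 3 to compound 4 (0.05 log units; within the scatter), with chloro rather than fluoro on the aromatic carbon: the same change on two cores in this assay, a 1.2-fold higher number (0.08 log units; within the scatter) from compound 1 to compound 2 and a 1.1-fold higher number (0.05 log units; within the scatter) from compound 3 to compound 4, 1.1-fold (0.03 log units) apart, within the scatter of two such steps Chloro in place of fluoro likewise gives a flat step, a 1.1-fold higher number from compound 2 to compound 4 (0.06 log units; within the scatter), with methyl rather than isopropyl on the nitrogen: the same change on two cores in this assay, a 1.2-fold higher number (0.09 log units; within the scatter) from compound 1 to compound 3 and a 1.1-fold higher number (0.06 log units; within the scatter) from compound 2 to compound 4, 1.1-fold (0.03 log units) apart, within the scatter of two such steps Each change therefore carries between the two cores shown without a detectable difference, but this shows only that two flat steps stay flat; it does not show how either change would carry over to a core on which it moves the number beyond the scatter, or to cores beyond these four compounds.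

The compounds shown leave open whether a longer chain or a benzyl group on that nitrogen would shift the number. They also leave open whether a methoxy group, a nitrile or an amine in place of fluoro or chloro on the aromatic carbon would do so.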